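The compounds below may be only part of what the source reports. "The series", "measured", "known", "first", "only" and "open" are said of these compounds alone.

Working notes on the series. Going by the values given here, in a functional assay on the whole organism (Abdomen, strain Swiss) for inhibition, with Mus musculus as the target, with stated times of 30 min, 10 min and 5 min, at a dose of 20 mg/kg by the oral route (on this read-out lower numbers stand for a weaker effect and higher numbers for a stronger effect at the one dose given), compound 2 `O=c1occ(-c2ccccc2)n1CCCN1CCN(c2cccc(Cl)c2)CC1` gives 31%, the higher of the two numbers measured so far; its nearest neighbour, compound 1 `O=c1occ(-c2ccccc2)n1CCCN1CCN(c2ccc(F)cc2)CC1`, gives 12% in this assay. Among the compounds with values here, the one step available, a number 19 percentage points higher from compound 1 to compound 2 (beyond the scatter), is the only measured change at the aryl group on the piperazine nitrogen, and it reads as a modest rise beyond the scatter.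

Compound 3 `COc1cccc(N2CCN(CCCn3c(-c4ccccc4)coc3=O)CC2)c1` is next, differing from compound 2 by methoxy in place of chloro on an aromatic carbon. Within the data shown here, no measured step covers a methoxy group at this ring, so the only guidance is that a single change on this aryl moved this assay by a modest amount. The expectation is therefore a step of about a number 7 percentage points lower from compound 2 to compound 3 (within the scatter) from compound 2 to compound 3, with the sign uncertain and the range wide. Compound 3 is estimated at 24%, with a range from 5% to 48%.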

Compound 3, a percentage reported as inhibition, in the whole organism at one dose (the size of the read-out at that dose, not a potency): 25%
Compound 3: the middle estimate sits 1 percentage points below what was measured; measured number inside the range.
By their numbers in this assay, from the lowest: compound 1; then compounds 3 and 2 (each within the scatter of the next).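

In this assay, methoxy in place of chloro on the aromatic carbon gives a number 6 percentage points lower from compound 2 to compound 3 (within the scatter), so the read-out does not separate these two groups at this place on the ring. With 3-methoxyphenyl in place of 4-fluorophenyl, the series shows a number 13 percentage points higher from compound 1 to compound 3 (beyond the scatter), a second modest rise beyond the scatter from compound 1, although this change, like the first, alters both the group and its place on the ring. Nothing available bears on the reason for either result.

On these data alone, whether the rise from compound 1 follows the place on the ring or the group itself remains open, and fluoro on the same aromatic carbon would speak to that. Also open, as far as these compounds go, is whether a larger or different group there, such as trifluoromethyl, a nitrile or a hydroxyl, would move the read-out beyond the scatter.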